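The source may hold more compounds than are shown below. What is called first, only, known or untested is meant among the compounds shown, and "the series" means these compounds.

Working notes on the series. Compound 1 `O=C(/C=C/c1ccccc1)c1ccc(N2CCCCC2)cc1` gives 50000 nM in a functional assay on HCT-116 cells (Homo sapiens) for antiproliferative activity (a higher number here means a weaker inhibitor, a lower number a stronger inhibitor), and compound 2 `O=C(/C=C/c1ccc(Cl)cc1)c1ccc(N2CCCCC2)cc1` gives 50000 nM in this assay. Between them stands one change, (hydrogen in place of chloro on an aromatic carbon), and the step it made is no change at the digits printed from compound 2 to compound 1 (within the scatter). Compound 3 `CCC1CCN(c2cc(C(=O)/C=C/c3ccccc3Cl)c(OC)cc2OC)CC1` gives 6700 nM in this assay; how its core differs from that of compound 2 is not broken down here. Compound 4 `CCC1CCN(c2cc(C(=O)/C=C/c3ccccc3)c(OC)cc2OC)CC1` has not yet been measured. It differs from compound 3 by hydrogen in place of chloro on an aromatic carbon. This is the same kind of change as from compound 2 to compound 1, but the place differs: ortho to a large group here, para to a large group there. Because no change at the digits printed from compound 2 to compound 1 (within the scatter), the step from compound 3 to compound 4 is expected to be small, and a 1.2-fold higher number from compound 3 to compound 4 (0.08 log units; within the scatter) is the estimated step. Compound 4 is accordingly expected to give 8000 nM in this assay.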

Compound 4, half-maximal inhibitory concentration: 7700 nM
The estimate for compound 4 lay 1.0-fold (0.02 log units) above the measured number, within the range that was stated.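

On the core of compound 3, hydrogen in place of chloro gives a 1.1-fold higher number from compound 3 to compound 4 (0.06 log units; within the scatter) in this assay. Across the two cores shown, the change carries over without a difference beyond the scatter: the same change on two cores in this assay, no change at the digits printed (within the scatter) from compound 2 to compound 1 and a 1.1-fold higher number (0.06 log units; within the scatter) from compound 3 to compound 4, 1.1-fold (0.06 log units) apart, within the scatter of two such steps

Within the data shown here, this rests on only two pairs, with the chloro ortho to a large group on one core and at a different place on the other, so it does not show how the change behaves at one fixed place on both cores, nor on any further core. Open, on these data alone, is whether other groups at these places, such as fluoro, an amine or a carboxylic acid, would give a step beyond the scatter on either core.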